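Swapping pyridinyl for thiophenyl on a weak inhibitor

The compounds below may be only part of what the source reports. "The series", "measured", "known", "first", "only" and "open" are said of these compounds alone.

Measured so far:
Compound 1 `Oc1ccc(-c2cc(-c3cccnc3)nc(-c3ccccc3Cl)c2)cc1`: 0.9%
Compound 2 `Oc1ccc(-c2cc(-c3cccnc3)nc(-c3cccc(Cl)c3)c2)cc1`: 55.2%
Compound 3 `Oc1cccc(-c2cc(-c3cccc(Cl)c3)nc(-c3ccco3)c2)c1`: 5.5%

The three compounds were tested in an assay on isolated protein for inhibition of DNA topoisomerase 1 (Homo sapiens), with a stated time of 30 min, tested at 100 uM; a lower number here means a weaker effect, a higher number a stronger effect of the compound at the concentration tested. Compound 1 gives the lowest of the three numbers; compound 3 lies nearest to it, within the scatter, while compound 2 lies furthest away, beyond the scatter. Going by the values given here, the only one-step change among the measured compounds is a number 54.3 percentage points higher from compound 1 to compound 2 (beyond the scatter), and it concerns the chlorophenyl group, not the group that is exchanged here.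

Compound 4 `Oc1ccc(-c2cc(-c3ccsc3)nc(-c3ccccc3Cl)c2)cc1` is not yet measured. It differs from compound 1 as follows: thiophen-3-yl in place of pyridin-3-yl on an aromatic carbon. Among the compounds with values here, no measured step touches this position, so nothing among the data points to a change in either direction. The account therefore expects a step for compound 4 of about a number 4.1 percentage points higher from compound 1 to compound 4 (within the scatter), that is, none beyond the scatter. Compound 4 is estimated at 5%, with a range from 0% to 20%.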

Compound 4, a percentage reported as inhibition, at one concentration (the size of the read-out at that concentration, not a potency): 4.1%
Estimate against measurement, compound 4: 0.9 percentage points above, and the stated range covers the measured number.
By their numbers in this assay, from the lowest: compounds 1, 4 and 3 (each within the scatter of the next); then compound 2.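

In this assay, thiophen-3-yl in place of pyridin-3-yl, on the aromatic carbon next to the ring nitrogen of the shared core, gives a number 3.2 percentage points higher from compound 1 to compound 4 (within the scatter). Going by these compounds alone, this is the first view of this position: with the 2-chlorophenyl group in place, a five-membered aromatic ring with sulfur does not read differently from a six-membered aromatic ring with nitrogen. Since compound 1 already gives 0.9%, however, a loss could hardly show here, and nothing at hand explains the result.

As far as these compounds go, whether thiophen-3-yl would be tolerated equally with the 3-chlorophenyl group of compound 2, at 55.2%, remains open. From the compounds shown here alone, it is also open what a carboxylic acid or a morpholine at this position would give.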